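The compounds below may be only part of what the source reports. "The series", "measured", "known", "first", "only" and "open" are said of these compounds alone.

Compound 1 `COc1cc(C(=O)N2CCC(O)C(C)C2)cc2nc(NCc3cccc(Cl)c3)oc12`: 45 mL/min/kg
Compound 2 `COc1cc(C(=O)N2CC[C@H](O)[C@@H](C)C2)cc2nc(NCc3cccc(Cl)c3)oc12`: 36.7 mL/min/kg
Compound 3 `CCC1CC(O)C(C)CN1C(=O)c1cc(OC)c2oc(NCc3cccc(Cl)c3)nc2c1`: 61.7 mL/min/kg

All three values come from an ADME assay on cells (Hepatocyte, Rattus norvegicus, strain Wistar) for pharmacokinetics, read by LC-MS, with a stated time of 90 min, tested at 1 uM; a higher number here means faster removal of the compound, a lower number slower removal. The numbers do not separate compound 3 from the other two, as the record shows a 1.4-fold higher number from compound 1 to compound 3 (0.14 log units; within the scatter), and also a 1.7-fold higher number from compound 2 to compound 3 (0.23 log units; within the scatter).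

Compound 4 `COc1cc(C(=O)N2CC(C)C(O)CC2C2CC2)cc2nc(NCc3cccc(Cl)c3)oc12` carries cyclopropyl in place of ethyl on a saturated ring carbon, next to the ring nitrogen: cyclopropyl in place of ethyl on a saturated ring carbon.

The most relevant measured change is at this same ring carbon, where ethyl in place of hydrogen gave a 1.4-fold higher number from compound 1 to compound 3 (0.14 log units; within the scatter). Even this change, from hydrogen to ethyl, stayed within the scatter. The other comparison, a 1.2-fold lower number from compound 1 to compound 2 (0.09 log units; within the scatter), concerns only how the stereocentres are drawn, so it says little here. Within the data shown here, no measured step replaces ethyl with another group, which leaves the evidence indirect.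

No step beyond the scatter is therefore expected in this assay, and the estimated step is a 1.1-fold lower number from compound 3 to compound 4 (0.03 log units; within the scatter). For compound 4 the estimated clearance is 58 mL/min/kg, with an expected range of 38 mL/min/kg to 85 mL/min/kg.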

Compound 4, clearance: 63.3 mL/min/kg
For compound 4 the middle estimate is 1.1-fold (0.04 log units) below the measured one; measured number inside the range.
By their numbers in this assay, from the lowest: compounds 2, 1, 3 and 4 (each within the scatter of the next).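

In this assay, among these compounds, the earlier compounds showed only a change from hydrogen to ethyl at this ring carbon, whereas a 1.0-fold higher number from compound 3 to compound 4 (0.01 log units; within the scatter) now tests a second group that brings a three-membered ring with it. Cyclopropyl and ethyl give the same picture against the compounds without a group here: a 1.4-fold higher number from compound 1 to compound 4 (0.15 log units; within the scatter) and a 1.7-fold higher number from compound 2 to compound 4 (0.24 log units; within the scatter) are both small steps, so neither group stands apart from hydrogen at this position. No information at hand bears on why this change left the number where it was.

Still open, going by these compounds, is whether a longer chain such as butyl, or an amine or a carboxylic acid, at this ring carbon would move the number beyond the scatter. Also open, on these data alone, is how the configuration at this carbon matters, since compound 3 and compound 4 are drawn without one.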